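A few compounds are considered here, and "the series" means these few. Any claim that something is new, unique, unknown or untested is made for them only; others in the source may bear on it.

Compound 1 `COc1cccc(NC(=O)c2c(NO)cc(-c3ccccc3)oc2=O)c1` — > 20000 nM
Compound 2 `CCOc1ccccc1NC(=O)c1c(NO)cc(-c2ccccc2)oc1=O` — > 20000 nM

Both compounds were tested in an ADME assay on Huh-7 cells (Homo sapiens) for cytotoxicity, with a stated time of 3 days; on this read-out lower numbers stand for higher toxicity in this test and higher numbers for lower toxicity in this test. Compound 1 reaches only the limit of the assay there, so > 20000 nM is a limit rather than a number. For compound 2 the same holds, and > 20000 nM is likewise a limit and not a measured number. Since neither value is a number, the step that the two limits leave unreadable from compound 1 to compound 2 cannot be read in size or direction, both values sitting at the same limit (the limit of > 20000 nM in this assay, at which 2 of the 2 values shown sit).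

The next compound is compound 3 `Nc1ccccc1NC(=O)c1c(NO)cc(-c2ccccc2)oc1=O`. Its change from compound 2 is amino in place of ethoxy on an aromatic carbon. Among the compounds with values here, the only measured step that bears on this change is a step that the two limits leave unreadable from compound 1 to compound 2, and that step is unreadable. Within the data shown here, nothing in the numbers so far therefore points to a step in either direction beyond the scatter in this assay. The expectation is that compound 3 will also sit at the limit. The expected step is a step that the limit leaves unreadable from compound 2 to compound 3. For compound 3 the estimate is 25000 nM, with a range from 8000 nM to 80000 nM.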

Compound 3, half-maximal cytotoxic concentration: > 20000 nM
Compound 3 gave a limit, no number; the forecaster's own chance of this, stated with the estimate: 80%; the middle value lies beyond the limit too.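

In this assay compound 3 gives > 20000 nM as a limit, not a number. Within the data shown here, no step among compound 1, compound 2 and compound 3 can therefore be read in size or direction: the limit of > 20000 nM in this assay, at which 3 of the 3 values shown sit. The compounds shown leave open how their cytotoxicity compares, and whether amino in place of ethoxy changes it at all.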